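Compound 3: Free Amine in Place of the Acylated Nitrogen

A few compounds are considered here, and "the series" means these few. Any claim that something is new, unique, unknown or untested is made for them only; others in the source may bear on it.

Measured so far:
- compound 1 `Nc1ccc(/C=C2\SC(=O)N(Cc3ccc(F)cc3)C2=O)cc1` gives 111000 nM in a functional assay on CCRF-CEM cells (Homo sapiens) for cytotoxicity, read by cell counting, with a stated time of 3 days; on this read-out lower numbers stand for stronger inhibition and higher numbers for weaker inhibition
- compound 2 `C=C(Br)C(=O)Nc1ccc(/C=C2\SC(=O)N(C)C2=O)cc1` gives 360 nM in this assay

Compound 2 stands lowest of the two numbers, and compound 1 sits far higher, beyond the scatter. Compound 3 `CN1C(=O)S/C(=C\c2ccc(N)cc2)C1=O` differs from compound 2 by hydrogen in place of (1-bromoethenyl)carbonyl on a nitrogen on an aromatic ring. Compound 1 also carries a free amino group on its ring and gives a weak number, 111000 nM. Within the data shown here, no measured step covers this exact change, so the expectation rests on compound 1. Compound 3 is expected to be much weaker, with the step of a 140-fold higher number from compound 2 to compound 3 (2.14 log units; beyond the scatter) estimated to run toward higher numbers, well beyond the scatter. Compound 3 is estimated at 50000 nM, within 10000 nM to 200000 nM.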

Compound 3, half-maximal inhibitory concentration: 62000 nM
The estimate for compound 3 lay 1.2-fold (0.09 log units) below the measured number; the measured number falls inside the stated range.
By their numbers in this assay, from the lowest: compound 2; then compounds 3 and 1 (each within the scatter of the next).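

In this assay, taking away the (1-bromoethenyl)carbonyl to leave a free amino group loses almost all activity (a 170-fold higher number from compound 2 to compound 3 (2.24 log units; beyond the scatter)), so the potency of compound 2 depends on this group on the nitrogen. With the amino group free, hydrogen in place of 4-fluorophenyl on the saturated chain carbon changes nothing beyond the scatter (a 1.8-fold lower number from compound 1 to compound 3 (0.25 log units; within the scatter)). Nothing here explains why the acyl group matters so much. Still open, going by these compounds, is whether the bromine is needed, or whether a simple acetyl group on this nitrogen would do as well. Also open, on these data alone, is whether 4-fluorophenyl matters once the (1-bromoethenyl)carbonyl is present.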